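Compound 2 to compound 3: amide-type nitrogen substituent

The source may hold more compounds than are shown below. What is called first, only, known or untested is meant among the compounds shown, and "the series" means these compounds.

Going by the values given here, in a functional assay on Shh Light II cells (Mus musculus) for inhibition, read by a luciferase reporter (a lower number here means a stronger inhibitor, a higher number a weaker inhibitor), two compounds have numbers so far. Compound 1 `COc1ccccc1N(C)C(=O)N1CCC(c2nc(-c3ccc4ccccc4n3)no2)CC1` reads 3100 nM and compound 2 `O=C(NC1CCOCC1)N1CCC(c2nc(-c3ccc4ccccc4n3)no2)CC1` reads 480 nM and so holds the lower of the two numbers.

Compound 3 `Cc1noc(C)c1NC(=O)N1CCC(c2nc(-c3ccc4ccccc4n3)no2)CC1` keeps the shared core and carries 3,5-dimethyl-1,2-oxazol-4-yl in place of oxan-4-yl on an amide-type nitrogen.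

Among the compounds with values here, one measured step bears on this change: (oxan-4-yl)amino in place of (2-methoxyphenyl)(methyl)amino on a carbonyl carbon (a 6.5-fold lower number from compound 1 to compound 2 (0.81 log units; beyond the scatter)), which lies beyond the scatter. It is only a partial guide. Compound 3 shares an aromatic ring on that nitrogen with compound 1 (at 3100 nM) but keeps the amide hydrogen of compound 2 (at 480 nM). The two measured compounds cannot separate these features, so the evidence points neither way with any force.

In this assay the expected step is small, at most a slightly higher number, and stays within the scatter (estimated a 1.5-fold higher number from compound 2 to compound 3 (0.16 log units; within the scatter)).

For compound 3 the expected value is 700 nM (estimated range 180 nM to 2700 nM).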

Compound 3, half-maximal inhibitory concentration: 3000 nM
The estimate for compound 3 lay 4.3-fold (0.63 log units) below the measured number, outside the stated range (above it).
By their numbers in this assay, from the lowest: compound 2; then compounds 3 and 1 (each within the scatter of the next).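

In this assay the change to 3,5-dimethyl-1,2-oxazol-4-yl on the amide-type nitrogen gives a 6.3-fold higher number from compound 2 to compound 3 (0.80 log units; beyond the scatter) and so shows that keeping the amide hydrogen is not enough to hold the number of compound 2. The comparison of the two aromatic-ring compounds gives a 1.0-fold lower number from compound 1 to compound 3 (0.01 log units; within the scatter) and so leaves them level, although compound 3 has the amide hydrogen and compound 1 has a methyl group there; across these three compounds, the lowest number goes with oxan-4-yl, the only non-aromatic ring on that nitrogen, and none of the three goes against this. Nothing available accounts for the size of either step.

Still open, on these data alone, is whether the aromatic ring itself or the two methyl groups of the 3,5-dimethyl-1,2-oxazol-4-yl group go with the higher number, a question that phenyl, cyclohexyl or unsubstituted 1,2-oxazol-4-yl on the same nitrogen would help to separate. Also open, as far as these compounds go, is how the oxan-4-yl compound would read with a methyl group in place of the amide hydrogen, and whether an amine-bearing ring such as piperidin-4-yl would read like oxan-4-yl.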